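Propyl to allyl on a carbamate: a small step expected

The compounds below may be only part of what the source reports. "The series", "measured", "known", "first", "only" and "open" are said of these compounds alone.

Of the compounds shown here, three have been measured in a functional assay on MCF7 cells (Homo sapiens) for cytotoxicity, read by MTT assay, with a stated time of 72 h; on this read-out lower numbers stand for stronger inhibition of growth and higher numbers for weaker inhibition of growth. Compound 1 `CC(C)COC(=O)Nc1ccc([Se][Se]c2ccc(NC(=O)OCC(C)C)cc2)cc1` gives 19000 nM, compound 2 `CCCOC(=O)Nc1ccc([Se]C#N)cc1` gives 8000 nM, and compound 3 `CCOC(=O)Nc1ccc([Se][Se]c2ccc(NC(=O)OCC)cc2)cc1` gives 9900 nM. The number for compound 2 is the lowest of the three, but compound 3 sits within the scatter of it, and only the gap to compound 1 lies beyond the scatter. Compound 4 `C=CCOC(=O)Nc1ccc([Se]C#N)cc1` has not been measured. It differs from compound 2 by vinyl in place of ethyl on a saturated chain carbon bound to an oxygen next to a carbonyl group. Within the data shown here, no measured pair shows this change, so compound 4 is expected to stay close to compound 2, with the step from compound 2 to compound 4 estimated as no change at the digits printed from compound 2 to compound 4 (within the scatter), not beyond the scatter in either direction. Compound 4 is therefore expected to give about 8000 nM in this assay, within 4000 nM to 16000 nM.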

Compound 4, concentration for 50% growth inhibition: 15000 nM
Beside the measured number, compound 4's estimate is 1.9-fold (0.27 log units) below it, and the stated range covers the measured number.
By their numbers in this assay, from the lowest: compounds 2, 3, 4 and 1 (each within the scatter of the next, the first and the last beyond it).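

In this assay, among these compounds, the change from propyl to allyl gives a 1.9-fold higher number from compound 2 to compound 4 (0.27 log units; within the scatter), the first step between compounds that differ in one place. At this place, on a saturated chain carbon bound to an oxygen next to a carbonyl group, vinyl in place of ethyl therefore leaves the number within the scatter. No available evidence accounts for this step. On these data alone, whether a longer chain or a terminal amine at this place would also stay within the scatter remains open. So does whether the same change would act alike on the core of compound 3.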